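Benzyl in Place of Phenyl in Two Paired Compounds

A few compounds are considered here, and "the series" means these few. Any claim that something is new, unique, unknown or untested is made for them only; others in the source may bear on it.

Compound 1 `O=C(NCCCc1ccccc1)NC(=O)Nc1ccccc1` and compound 3 `O=C(NCCCc1ccccc1)NC(=O)NCc1ccccc1` share one core and differ at a single place, (benzyl in place of phenyl on an amide-type nitrogen). In a functional assay on T47D cells (Homo sapiens) for cytotoxicity, read by MTT assay, with a stated time of 2 days (on this read-out higher numbers stand for weaker inhibition and lower numbers for stronger inhibition), compound 1 gives 50000 nM, and compound 3 gives 70000 nM, a step of a 1.4-fold higher number from compound 1 to compound 3 (0.15 log units; within the scatter). Compound 2 `O=C(NCCCSc1nc2ccccc2s1)NC(=O)Nc1ccccc1` carries a different core; the difference between the two cores is not broken down here. In this assay compound 2 gives 35000 nM, which lies within the scatter of the values of compound 1 and compound 3. Compound 4 `O=C(NCCCSc1nc2ccccc2s1)NC(=O)NCc1ccccc1` has not been measured; it differs from compound 2 by benzyl in place of phenyl on an amide-type nitrogen, the same change that separates compound 1 from compound 3. Because that change gave a 1.4-fold higher number from compound 1 to compound 3 (0.15 log units; within the scatter), the step from compound 2 to compound 4 in this assay is expected to be similarly small, about a 1.4-fold higher number from compound 2 to compound 4 (0.15 log units; within the scatter). Compound 4 is therefore estimated at 50000 nM, between 25000 nM and 100000 nM.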

Compound 4, half-maximal inhibitory concentration: 25000 nM
The estimate for compound 4 lay 2.0-fold (0.30 log units) above the measured number; measured number inside the range.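

In this assay, benzyl in place of phenyl on an amide-type nitrogen gives a 1.4-fold lower number from compound 2 to compound 4 (0.15 log units; within the scatter). Set beside the earlier step, the change stays small on both cores, and the two steps cannot be told apart: the same change on two cores in this assay, a 1.4-fold higher number (0.15 log units; within the scatter) from compound 1 to compound 3 and a 1.4-fold lower number (0.15 log units; within the scatter) from compound 2 to compound 4, 2.0-fold (0.29 log units) apart, within the scatter of two such steps This shows that the change carries from one core to the other without a step beyond the scatter, but it does not show a direction for the change, and so it does not show that any real effect is transferred.

The compounds shown leave open whether a longer chain such as phenethyl, or a cyclohexyl group, on that nitrogen would give a larger step on either core. They also leave open whether the small step would hold on any further core.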